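Triazole aryl swap: hydroxyphenyl analogue of compound 1

This account rests on a few compounds, and the source may have more. Where it says the series, first, only, none or still open, it means among the compounds named here.

Compound 1 `CC1(C)[C@H]2CC[C@]1(C)N(Cc1cn(-c3cccc(F)c3)nn1)C(=O)C2` is the weakest of the three measured compounds in a functional assay on LoVo cells (Homo sapiens) for inhibition, read by MTT assay, with a stated time of 24 h (on this read-out lower numbers stand for stronger inhibition and higher numbers for weaker inhibition), where compound 1 gives 90 nM. Compound 2 `CC1(C)[C@H]2CC[C@]1(C)N(Cc1cn(-c3ccc(F)cc3)nn1)C(=O)C2` gives 40 nM and compound 3 `CC1(C)[C@H]2CC[C@]1(C)N(Cc1cn(-c3cccc(Cl)c3)nn1)C(=O)C2` gives 70 nM. The move from compound 1 to compound 2 is a 2.3-fold lower number from compound 1 to compound 2 (0.35 log units; beyond the scatter), while the move from compound 1 to compound 3 is a 1.3-fold lower number from compound 1 to compound 3 (0.11 log units; within the scatter); compound 2 and compound 3 sit close, a 1.8-fold higher number from compound 2 to compound 3 (0.24 log units; within the scatter).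

Compound 4 `CC1(C)[C@H]2CC[C@]1(C)N(Cc1cn(-c3ccc(O)cc3)nn1)C(=O)C2` differs from compound 1 in one place: 4-hydroxyphenyl in place of 3-fluorophenyl on an aromatic nitrogen. Among the compounds with values here, two measured steps bear on it. Shifting the substituent from the 3-fluorophenyl to the 4-fluorophenyl pattern gave a 2.3-fold lower number from compound 1 to compound 2 (0.35 log units; beyond the scatter), a modest gain; exchanging one halogen for another at the same place gave a 1.3-fold lower number from compound 1 to compound 3 (0.11 log units; within the scatter), nothing beyond the scatter. Within the data shown here, no measured pair tells what a hydroxy group does here. A modest lowering in this assay is therefore expected, about the size seen from compound 1 to compound 2, with a wide range to cover the untested group.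

Compound 4 is estimated at 55 nM in this assay, between 20 nM and 200 nM, an expected step of a 1.6-fold lower number from compound 1 to compound 4 (0.21 log units; within the scatter).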

Compound 4, half-maximal inhibitory concentration: 410 nM
For compound 4 the middle estimate is 7.5-fold (0.87 log units) below the measured one, outside the stated range (above it).
By their numbers in this assay, from the lowest: compounds 2, 3 and 1 (each within the scatter of the next, the first and the last beyond it); then compound 4.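

Among the aryl groups on the aromatic nitrogen, 4-hydroxyphenyl is the first to give a clear rise in the number in this assay, both against 3-fluorophenyl (a 4.6-fold higher number from compound 1 to compound 4 (0.66 log units; beyond the scatter)) and against 3-chlorophenyl (a 5.9-fold higher number from compound 3 to compound 4 (0.77 log units; beyond the scatter)). Within the data shown here, the sharpest contrast comes from the single exchange of hydroxy for fluoro on an aromatic carbon (a 10-fold higher number from compound 2 to compound 4 (1.01 log units; beyond the scatter)), so the 4-substituted phenyl pattern does not by itself keep the lower numbers of compound 2; the group it carries matters here. No evidence is available on what lies behind this loss.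

The compounds shown leave open whether the loss is specific to hydroxy or would also appear with a methoxy group, an amine or a carboxylic acid in its place. They also leave open how a 3-hydroxyphenyl group would compare with compound 4.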